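Acid analogues of the indole enone series: cyanobenzyl step

The source may report more compounds than this note shows. Statements on the series, on what has been measured and on what is new or still open speak of the compounds shown alone.

Within the data shown here, compound 3 `CC(C)CCn1cc(/C=C/C(=O)CC(=O)C(=O)O)c2ccccc21` is the one member with a number in an assay on isolated protein for inhibition of DNA nucleotidylexotransferase (Homo sapiens), read by scintillation counting, with a stated time of 10 min; on this read-out higher numbers stand for weaker inhibition and lower numbers for stronger inhibition: compound 3 gives 16.3 uM. Compound 1 `CCOC(=O)C(=O)CC(=O)/C=C/c1cn(CCC(C)C)c2ccccc12` sits at a limit of the assay, giving > 40 uM in this assay. Compound 2 `CCOC(=O)C(=O)CC(=O)/C=C/c1cn(Cc2ccc(F)cc2)c2ccccc12` likewise sits at a limit, giving > 40 uM in this assay. The free acid thus reads as the sole quantified point, with an at least 2.4-fold lower number from compound 1 to compound 3 (0.38 log units; beyond the scatter) marking the step from the ester to it. The replacement of the chain substituent was only tried within the ester pair, and there a step that the two limits leave unreadable from compound 1 to compound 2, because both values rest at the limit of > 40 uM in this assay, at which 2 of the 3 values shown sit, cannot be read in size or direction.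

Compound 4 `N#Cc1ccc(Cn2cc(/C=C/C(=O)CC(=O)C(=O)O)c3ccccc32)cc1` carries the acid of compound 3 together with a new group: 4-cyanophenyl in place of isobutyl on a saturated chain carbon bound to an aromatic nitrogen. Among the measured compounds shown here, no measured step shows what this exchange does when the acid is present, and the ester pair gives no readable size. The expectation for compound 4 is therefore a step of a 1.1-fold lower number from compound 3 to compound 4 (0.04 log units; within the scatter), with no change beyond the scatter assumed, and an estimated value of 15 uM, within a range of 5 uM to 45 uM.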

Compound 4, concentration for 50% inhibition: 1.4 uM
Estimate against measurement, compound 4: 11-fold (1.03 log units) above; the measured number lies below the stated range.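

Among these compounds, with the free acid in place, the substituent on the saturated chain carbon bound to the aromatic nitrogen becomes readable for the first time: in this assay, 4-cyanophenyl in place of isobutyl gives a 12-fold lower number from compound 3 to compound 4 (1.07 log units; beyond the scatter). The ester pair of compound 1 and compound 2 could show no such effect of this position because neither gives a number: the limit of > 40 uM in this assay, at which 2 of the 4 values shown sit. The acid series therefore responds to this change, and the isopentyl to 4-cyanobenzyl exchange is a large step rather than a neutral swap.

As far as these compounds go, it remains open whether the step comes from the aromatic ring or from the nitrile, which an unsubstituted benzyl group on the acid would help to separate. From the compounds shown here alone, how the 4-fluorophenyl group of compound 2 behaves alongside the acid also remains open.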